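The source may report more compounds than this note shows. Statements on the series, on what has been measured and on what is new or still open speak of the compounds shown alone.

Compound 3 `Nc1ccccc1NC(=O)c1ccc(CSC(=S)N2CCN(c3ccncc3)CC2)cc1` stands highest of the three compounds in a functional assay on A-375 cells (Homo sapiens) for antiproliferative activity, read by CCK-8 assay, with a stated time of 72 h, tested at 2 uM (a lower number here means a weaker effect, a higher number a stronger effect of the compound at the concentration tested), where compound 3 gives 85.7%. Compound 2 `Nc1ccccc1NC(=O)c1ccc(CSC(=S)N2CCN(c3ccccc3)CC2)cc1` gives 27.5% and compound 1 `Nc1ccccc1NC(=O)c1ccc(CSC(=S)N2CCN(Cc3ccccn3)CC2)cc1` gives 20.7%; the two differ by a number 6.8 percentage points higher from compound 1 to compound 2 (within the scatter), whereas a number 58.2 percentage points higher from compound 2 to compound 3 (beyond the scatter) and a number 65 percentage points higher from compound 1 to compound 3 (beyond the scatter) are both large. Compound 4 `Nc1ccccc1NC(=O)c1ccc(CSC(=S)N2CCN(C3CCCCC3)CC2)cc1` differs from compound 3 by cyclohexyl in place of pyridin-4-yl on an amine nitrogen in a ring. The step from compound 2 to compound 3, a number 58.2 percentage points higher from compound 2 to compound 3 (beyond the scatter), bears most closely on this change, since phenyl, like cyclohexyl, carries no ring nitrogen. Compound 4 is therefore expected to lose much of what compound 3 shows, a downward step of a number 55.7 percentage points lower from compound 3 to compound 4 (beyond the scatter) in this assay. Compound 4 is estimated at 30%, between 15% and 55%.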

Compound 4, a percentage reported as inhibition, at one concentration (the size of the read-out at that concentration, not a potency): 31.7%
Compound 4: middle estimate off by 1.7 percentage points, on the low side; the range from low to high includes it.
By their numbers in this assay, from the lowest: compounds 1, 2 and 4 (each within the scatter of the next, the first and the last beyond it); then compound 3.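

Swapping pyridin-4-yl for cyclohexyl removes most of the effect, with a number 54 percentage points lower from compound 3 to compound 4 (beyond the scatter) in this assay, while the non-aromatic carbon ring and the aromatic phenyl ring stand level, with a number 4.2 percentage points higher from compound 2 to compound 4 (within the scatter) here. A ring nitrogen alone does not mark out the active compound: compound 1 carries one in its (pyridin-2-yl)methyl group and goes against that reading, with a number 11 percentage points higher from compound 1 to compound 4 (beyond the scatter) on moving to a group without nitrogen. Nothing available explains why pyridin-4-yl stands apart.

Still open, on these data alone, is whether the effect depends on where the ring nitrogen sits, as pyridin-3-yl or pyridin-2-yl on the same amine nitrogen would show, or on direct attachment of the ring, as pyridin-4-ylmethyl would show.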